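The compounds below may be only part of what the source reports. "The series", "measured", "known", "first", "only" and "open" are said of these compounds alone.

Compound 2, `CC1=CC[C@H](C(C)C)c2cc(C)c(OC(=O)c3ccc(C(F)(F)F)cc3)cc21`, was tested in a functional assay on PC-3 cells (Homo sapiens) for antiproliferative activity, read by sulforhodamine B assay, with a stated time of 48 h, tested at 50 uM (on this read-out higher numbers stand for more inhibition at the one concentration tested (going by the name of the read-out) and lower numbers for less inhibition), where compound 2 gives 12.3%. Among the compounds with values here, only one other compound has a number here: compound 1, `COc1cccc(C(=O)Oc2cc3c(C)ccc(C(C)C)c3cc2C)c1`, which in this assay gives 12.5%. Compound 2 thus stands lowest of the two, but its nearest neighbour, compound 1, lies within the scatter of repeated measurements, so the two numbers cannot be told apart. The next compound, compound 3, `COc1ccc(C(=O)Oc2cc3c(cc2C)[C@@H](C(C)C)CC=C3C)cc1`, differs from compound 2 in one place: methoxy in place of trifluoromethyl on an aromatic carbon. Within the data shown here, no step between two measured compounds that differ in one place is available, so there is nothing to calibrate the change against. Both measured numbers are low, and on that basis the expected step of a number 0.7 percentage points higher from compound 2 to compound 3 (within the scatter) is none beyond the scatter. Compound 3 is therefore estimated in this assay at 13%, with a range from 0% to 30%.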

Compound 3, a percentage reported as inhibition, at one concentration (the size of the read-out at that concentration, not a potency): 60.6%
Estimate against measurement, compound 3: 47.6 percentage points below; the whole stated range lies below it.
By their numbers in this assay, from the lowest: compounds 2 and 1 (each within the scatter of the next); then compound 3.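

In this assay, methoxy in place of trifluoromethyl on an aromatic carbon, para to a large group, gives a number 48.3 percentage points higher from compound 2 to compound 3 (beyond the scatter). The earlier numbers were all low and gave no sign of this: they left open whether this position mattered at all, and now a swap at this one place is seen to separate a low number from a much higher one. No measurement at hand explains the step.

As far as these compounds go, it remains open whether the higher number belongs to methoxy alone or would also come with a hydroxyl group, an amine, a carboxylic acid or a longer chain such as ethoxy on the same carbon. From the compounds shown here alone, it is also open whether the same swap would give a similar step on the core of compound 1.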